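Moving the oxolane attachment point on the side chain

A few compounds are considered here, and "the series" means these few. Any claim that something is new, unique, unknown or untested is made for them only; others in the source may bear on it.

Measured compounds:
- Compound 1, `Cc1cc(C)c(CN2CCc3c(Cl)cc([C@H](CO)[C@H]4CCOC4)c(Cl)c3C2=O)c(=O)[nH]1`: 10 nM
- Compound 2, `COC(c1cc(Cl)c2c(c1Cl)C(=O)N(Cc1c(C)cc(C)[nH]c1=O)CC2)C1CCOC1`: 1100 nM; 494 nM; 47 nM; 7 nM (4 entries)
- Compound 3, `COC(c1cc(Cl)c2c(c1Cl)C(=O)N(Cc1c(C)cc(C)[nH]c1=O)CC2)C1CCOCC1`: 1460 nM; 9 nM (2 entries)

All three compounds share the same core and differ only in the side chain that carries an oxolane ring. For the measured compounds named here, in an assay on cells for inhibition of histone-lysine N-methyltransferase EZH2 (Homo sapiens), read by ELISA, with a stated time of 72 h (on this read-out lower numbers stand for stronger inhibition and higher numbers for weaker inhibition), compound 1 gives 10 nM, the single clear number among the three, whereas the entries for compound 2 the several entries of compound 2 in this assay, 1100 nM; 494 nM; 47 nM; 7 nM (4 entries) and for compound 3 the several entries of compound 3 in this assay, 1460 nM; 9 nM (2 entries) spread widely and cannot be reduced to one value. Compound 1 therefore serves as the anchor for the next step.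

Compound 4, `Cc1cc(C)c(CN2CCc3c(Cl)cc([C@H](CO)[C@H]4CCCO4)c(Cl)c3C2=O)c(=O)[nH]1`, keeps every atom of compound 1 but joins them differently: oxolan-2-yl in place of oxolan-3-yl on a saturated chain carbon bound to an aromatic carbon and a saturated chain carbon. Going by the values given here, no measured pair in this set captures that exact rearrangement, so its effect in this assay is open. A change of this kind, which keeps the ring and its single oxygen and only moves where the ring is attached, is expected to produce a step that stays close to the usual scatter, with no firm direction. On that basis compound 4 is expected to give 15 nM, within a range of 4 nM to 60 nM, which means an expected step of a 1.5-fold higher number from compound 1 to compound 4 (0.18 log units; within the scatter).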

Compound 4, half-maximal inhibitory concentration in the histone-lysine N-methyltransferase EZH2 assay: 40 nM
For compound 4 the middle estimate is 2.7-fold (0.43 log units) below the measured one; measured number inside the range.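

For the compounds shown here, this is the first step in the set between compounds that differ in one place, so it is the first direct reading of this position; none could be taken from compound 1, compound 2 and compound 3, and in the histone-lysine N-methyltransferase EZH2 assay compound 1 gives 10 nM. For compound 2 the data print: the several entries of compound 2 in the histone-lysine N-methyltransferase EZH2 assay, 1100 nM; 494 nM; 47 nM; 7 nM (4 entries). For compound 3 the data print: the several entries of compound 3 in the histone-lysine N-methyltransferase EZH2 assay, 1460 nM; 9 nM (2 entries). In the histone-lysine N-methyltransferase EZH2 assay, replacing oxolan-3-yl with oxolan-2-yl on a saturated chain carbon bound to an aromatic carbon and a saturated chain carbon gives a 4.0-fold higher number from compound 1 to compound 4 (0.60 log units; beyond the scatter), a modest step that shows the attachment point of the ring counts, even though the ring and its single oxygen stay the same. In a physicochemical assay for lipophilicity, at pH 7.4 (a higher number here means a more lipophilic compound, a lower number a more polar compound), compound 1 gives 2 and compound 4 gives 2.1. In the physicochemical assay, the same change gives a number 0.10 log units higher from compound 1 to compound 4 (within the scatter), so this read-out does not separate the two compounds, while the histone-lysine N-methyltransferase EZH2 assay does.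

Nothing in the data shown explains why moving the attachment point changes the number. From the compounds shown here alone, it also remains open how the same place on the shared core would respond to a ring with a different atom in it, such as pyrrolidin-3-yl, which carries an amine, in place of the oxolane ring.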